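Swapping the aryl group on the triazole of compound 3

The source may hold more compounds than are shown below. What is called first, only, known or untested is meant among the compounds shown, and "the series" means these compounds.

Compound 1 `N#CC1=C(N)Oc2c(N)cc3nc4ccccc4nc3c2C12C(=O)N(Cc1cnnn1-c1ccc(F)cc1)c1ccccc12` — in a functional assay on HCT-116 cells (Homo sapiens) for antiproliferative activity, read by MTT assay, with a stated time of 48 h (on this read-out lower numbers stand for stronger inhibition and higher numbers for weaker inhibition), compound 1 gives > 50000 nM, which is a limit of the assay and not a number.
Compound 2 `N#CC1=C(N)Oc2c(N)cc3nc4ccccc4nc3c2C12C(=O)N(Cc1cnnn1-c1ccc([N+](=O)[O-])cc1)c1ccccc12` — compound 2 gives > 50000 nM, again a limit.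
Compound 3 `Cc1ccc(Cl)cc1-n1nncc1CN1C(=O)C2(C(C#N)=C(N)Oc3c(N)cc4nc5ccccc5nc4c32)c2ccccc21` — compound 3 gives 37200 nM.

Within the data shown here, compound 3 therefore holds the only actual number among the three; the other two values sit at the limit of > 50000 nM in this assay, at which 2 of the 3 values shown sit. Compound 4 `N#CC1=C(N)Oc2c(N)cc3nc4ccccc4nc3c2C12C(=O)N(Cc1cnnn1-c1ccc(Cl)cc1[N+](=O)[O-])c1ccccc12` differs from compound 3 in one place: 4-chloro-2-nitrophenyl in place of 5-chloro-2-methylphenyl on an aromatic nitrogen.

Among the measured compounds shown here, two measured steps bear on this change, and both end at compound 3: an at least 1.3-fold lower number from compound 1 to compound 3 (0.12 log units; that floor lies within the scatter), and an at least 1.3-fold lower number from compound 2 to compound 3 (0.12 log units; that floor lies within the scatter). Each is only a floor, and that floor lies within the usual scatter. The third step, a step that the two limits leave unreadable from compound 1 to compound 2, gives no size at all. For the measured compounds named here, compound 4 carries a nitro group, as compound 2 does, and a chlorine, as compound 3 does, but no measured step reads beyond the scatter, so no direction can be read off. The expectation for compound 4 in this assay is therefore a weak value near that of compound 3, quite possibly reported only as a limit: the expected step is a 1.2-fold higher number from compound 3 to compound 4 (0.08 log units; within the scatter). The estimated value for compound 4 is 45000 nM, with a range from 15000 nM to 120000 nM.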

Compound 4, half-maximal inhibitory concentration: 28700 nM
Beside the measured number, compound 4's estimate is 1.6-fold (0.20 log units) above it; the range from low to high includes it.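

In this assay, putting 4-chloro-2-nitrophenyl in place of 5-chloro-2-methylphenyl on the aromatic nitrogen gives a 1.3-fold lower number from compound 3 to compound 4 (0.11 log units; within the scatter), so this sizeable swap, which brings in a nitro group, removes a methyl group and changes where the chlorine sits, leaves compound 3 and compound 4 indistinguishable. Compared with the two simpler aryl groups, the same 4-chloro-2-nitrophenyl group gives an at least 1.7-fold lower number from compound 2 to compound 4 (0.24 log units; that floor lies within the scatter) and an at least 1.7-fold lower number from compound 1 to compound 4 (0.24 log units; that floor lies within the scatter), and neither floor shows a real gain, although compound 4 now provides a nitro-bearing compound with an actual number. These two steps remain floors and the step between compound 1 and compound 2 cannot be read, because neither of those compounds has an actual number: the limit of > 50000 nM in this assay, at which 2 of the 4 values shown sit.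

Among these compounds, it remains open whether any group on this aromatic nitrogen can move the number beyond the scatter, since every readable step so far stays within it. A phenyl ring carrying an amine or a carboxylic acid, or a plain alkyl chain in place of the aryl ring, would extend the comparison to groups of a different kind from the substituted phenyl rings shown here.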